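The source may hold more compounds than are shown below. What is called first, only, known or untested is meant among the compounds shown, and "the series" means these compounds.

Within the data shown here, in a functional assay on CFPAC-1 cells (Homo sapiens) for antiproliferative activity, read by MTT assay, with a stated time of 72 h (a higher number here means a weaker inhibitor, a lower number a stronger inhibitor), three compounds built on a shared core have numbers so far: compound 1 (`CCCCCc1ccc(-c2cn(C[C@H](O)[C@H]3OC(=O)C(OCc4ccccc4)=C3OCc3ccccc3)nn2)cc1`) gives 9890 nM, compound 2 (`O=C1O[C@H]([C@@H](O)Cn2cc(CNS(=O)(=O)c3ccc(Cl)cc3)nn2)C(OCc2ccccc2)=C1OCc1ccccc1`) gives 38900 nM and compound 3 (`O=C1O[C@H]([C@@H](O)Cn2cc(-c3cc(F)cc(F)c3)nn2)C(OCc2ccccc2)=C1OCc1ccccc1`) gives 62400 nM. Compound 3 stands at the high end of this small set, with a 1.6-fold higher number from compound 2 to compound 3 (0.21 log units; within the scatter) and a 6.3-fold higher number from compound 1 to compound 3 (0.80 log units; beyond the scatter). Compound 4 (`C[Si](C)(C)c1cn(C[C@H](O)[C@H]2OC(=O)C(OCc3ccccc3)=C2OCc2ccccc2)nn1`) changes the group on the same aromatic carbon: a group of 4 heavy atoms (3 carbon, 1 silicon; no ring) in place of a group of 8 heavy atoms (6 carbon, 2 fluorine; one six-membered aromatic ring of carbon only), on an aromatic carbon. The measured swaps there also include a 3.9-fold higher number from compound 1 to compound 2 (0.59 log units; beyond the scatter), so they were modest or smaller, and none brings in silicon. No step beyond the scatter is therefore expected in this assay, and the estimated change is a 1.6-fold lower number from compound 3 to compound 4 (0.19 log units; within the scatter). The estimate for compound 4 is 40000 nM, within a range from 13000 nM to 120000 nM.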

Compound 4, half-maximal inhibitory concentration: 52600 nM
The estimate for compound 4 lay 1.3-fold (0.12 log units) below the measured number; the measured number falls inside the stated range.
By their numbers in this assay, from the lowest: compound 1; then compounds 2, 4 and 3 (each within the scatter of the next).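

With a 1.2-fold lower number from compound 3 to compound 4 (0.07 log units; within the scatter) and a 1.4-fold higher number from compound 2 to compound 4 (0.13 log units; within the scatter) as its steps, a group of 4 heavy atoms that has no ring and carries silicon sits level with the 3,5-difluorophenyl group and the much larger sulfonamide-bearing group on this aromatic carbon, so a ring there is not needed to reach that level. Only the 4-pentylphenyl group stands apart, with a 5.3-fold higher number from compound 1 to compound 4 (0.73 log units; beyond the scatter) as the step to the silicon group.

From the compounds shown here alone, whether a tert-butyl group, the all-carbon counterpart of the silicon group, would match it, or a plain pentyl chain would approach the 4-pentylphenyl number, stays open. Nothing given here explains these numbers.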